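A methoxy group enters where compound 2 carries hydrogen

This account rests on a few compounds, and the source may have more. Where it says the series, first, only, none or still open, it means among the compounds named here.

Among the measured compounds shown here, compound 2 `N#CC1=C(N)N2C(=O)CSC2=C(C#N)C1c1ccccc1` stands at the top of the two numbers measured so far, though only by a margin within the scatter. In a functional assay on HCT-116 cells (Homo sapiens) for inhibition, read by MTT assay, with a stated time of 48 h, tested at 1 mg/mL (a lower number here means less inhibition, a higher number more inhibition at the concentration tested (going by the name of the read-out)), compound 2 gives 50.8%. Its nearest neighbour is compound 1 `N#CC1=C(N)N2C(=O)CSC2=C(C#N)C1c1ccc(F)cc1`, which in this assay gives 47.8%; the step of a number 3 percentage points higher from compound 1 to compound 2 (within the scatter) is within the scatter, so the two compounds cannot be told apart on these numbers.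

Compound 3 `COc1ccc(C2C(C#N)=C(N)N3C(=O)CSC3=C2C#N)cc1` differs from compound 2 in a single place: methoxy in place of hydrogen on an aromatic carbon. For the measured compounds named here, the only measured step that bears on this change is a number 3 percentage points higher from compound 1 to compound 2 (within the scatter), the one in which a substituent on an aromatic carbon of the same ring was exchanged, and that step stayed within the scatter. Going by the values given here, on that basis the expected step of a number 0.8 percentage points lower from compound 2 to compound 3 (within the scatter) in this assay is none beyond the scatter, with no direction favoured, and the uncertainty is wide since only one such exchange has been measured. The estimate for compound 3 in this assay is 50%, with a range from 35% to 65%.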

Compound 3, a percentage reported as inhibition, at one concentration (the size of the read-out at that concentration, not a potency): 50.2%
Compound 3: middle estimate off by 0.2 percentage points, on the low side; low and high end bracket the measured number.
By their numbers in this assay, from the lowest: compounds 1, 3 and 2 (each within the scatter of the next).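

In this assay the change to methoxy on an aromatic carbon para to a large group gives a number 0.6 percentage points lower from compound 2 to compound 3 (within the scatter) and so does not separate a bare hydrogen from a group of 2 heavy atoms carrying 1 hydrogen-bond acceptor. The exchange of fluoro for methoxy at the same place gives a number 2.4 percentage points higher from compound 1 to compound 3 (within the scatter) and, taken with the earlier step between fluoro and hydrogen, it leaves all three compounds within the scatter of one another, so that this position has now shown no measurable response to any of the three groups placed there, at least at the single concentration tested. Nothing measured here speaks to the reason for this flat reading.

What the compounds shown leave open is whether a group of another kind at this place, such as an amine, a carboxylic acid or a longer alkoxy chain, would move the number beyond the scatter. They also leave open whether compounds that read alike at one concentration would still read alike in potency, which a single-concentration percentage cannot tell.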